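The source may report more compounds than this note shows. Statements on the series, on what has been measured and on what is new or still open speak of the compounds shown alone.

Working notes on the series.

The series shares the core seen in compound 1 `O=C(O)Cc1sc(CSc2ccccc2)nc1-c1ccc(Cl)cc1`, which in an in vitro assay on HEK385-7 cells for displacement of a labelled ligand from prostaglandin D2 receptor 2 (Homo sapiens) (a higher number here means a weaker inhibitor, a lower number a stronger inhibitor), gives 250 nM. Compound 2 `O=C(O)Cc1sc(C(Cc2ccccc2)c2ccccc2)nc1-c1ccc(Cl)cc1` gives 56 nM in this assay. Compound 3 `NS(=O)(=O)c1ccc(-c2nc(C(c3ccc(F)cc3)c3ccc(F)cc3)sc2CC(=O)O)cc1` gives 1500 nM in this assay, the highest number of the three and beyond the scatter from both of the others; compound 2 holds the lowest number shown. Among the compounds with values here, no pair among the measured compounds differs in a single place, so no single step is available.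

Compound 4 `COc1cc(-c2nc(C(c3ccc(F)cc3)c3ccc(F)cc3)sc2CC(=O)O)ccn1` is not yet measured. It differs from compound 3 in one place: 2-methoxypyridin-4-yl in place of 4-sulfamoylphenyl on an aromatic carbon. Compound 3 stands at 1500 nM, while other aryl groups at that carbon give compound 1 250 nM and compound 2 56 nM; on this basis the expected step of a 3.8-fold lower number from compound 3 to compound 4 (0.57 log units; beyond the scatter) is toward a lower number, beyond the scatter. Compound 4 is estimated at 400 nM, in the range 120 nM to 1300 nM.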

Compound 4, half-maximal inhibitory concentration: 29 nM
Estimate against measurement, compound 4: 14-fold (1.14 log units) above; measured number outside the range, below it.
By their numbers in this assay, from the lowest: compounds 4 and 2 (each within the scatter of the next); then compound 1; then compound 3.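

In this assay, 2-methoxypyridin-4-yl in place of 4-sulfamoylphenyl on this aromatic carbon gives a 52-fold lower number from compound 3 to compound 4 (1.71 log units; beyond the scatter), the only single-place step shown, so a change at this position alone can move the number substantially. The exchange alters the ring, the substituent and the donor count together, and this one step cannot separate them. No measured evidence bears on the reason for the step.

Open, as far as these compounds go, is how a plain pyridin-4-yl or a 2-methoxyphenyl would stand at this carbon. Also open, from the compounds shown here alone, is whether the same exchange gives a step of similar size with another large group on the shared core.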